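Working notes: nitro for chloro, compound 1 to compound 4

This account rests on a few compounds, and the source may have more. Where it says the series, first, only, none or still open, it means among the compounds named here.

Measured so far, in a functional assay on L1210 cells (Mus musculus) for inhibition; a lower number here means a stronger inhibitor, a higher number a weaker inhibitor:
- compound 1 `O=C1/C(=C/c2ccccc2Cl)Cc2ccccc21` gives 152000 nM
- compound 2 `O=C1/C(=C/c2ccccc2F)CCc2ccccc21` gives 22800 nM
- compound 3 `O=C1/C(=C/c2ccc(Cl)cc2Cl)Cc2ccccc21` reaches only a limit of this assay, > 500000 nM

Compound 1 stands at the highest of the two numbers in this assay; the nearest number belongs to compound 2, which lies lower and beyond the scatter. The third value is the limit of compound 3 and not a number.

The step to be followed is nitro in place of chloro on an aromatic carbon, giving compound 4 `O=C1/C(=C/c2ccccc2[N+](=O)[O-])Cc2ccccc21`. Going by the values given here, no measured step exchanges one group for another on this aromatic carbon. Among the compounds with values here, the only measured step that touches this ring is an at least 3.2-fold higher number from compound 1 to compound 3 (0.51 log units; beyond the scatter), which sits at the limit of > 500000 nM in this assay, at which 1 of the 3 values shown sits, and therefore tells nothing of its size beyond the bound. Compound 2 differs from compound 1 in two places and so offers no single-place comparison.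

Within the data shown here, with no step bearing directly on the exchange, the expectation in this assay is a number for compound 4 close to that of compound 1, with no step beyond the scatter; the step of a 1.0-fold lower number from compound 1 to compound 4 (0.01 log units; within the scatter) is an estimate only. Compound 4 is therefore expected at about 150000 nM, in the range 40000 nM to 600000 nM.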

Compound 4, half-maximal inhibitory concentration: 7610 nM
The estimate for compound 4 lay 20-fold (1.29 log units) above the measured number; the whole stated range lies above it.
By their numbers in this assay, from the lowest: compound 4; then compound 2; then compound 1. At a limit, above all of these: compound 3.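

In this assay, exchanging the group on this aromatic carbon, ortho to a large group, gives a 20-fold lower number from compound 1 to compound 4 (1.30 log units; beyond the scatter), the only single-place step shown that moves towards a stronger inhibitor. Going by these compounds alone, the one other single-place step, an at least 3.2-fold higher number from compound 1 to compound 3 (0.51 log units; beyond the scatter), moves towards a weaker inhibitor and rests on the limit of compound 3, so this ring can shift the number in either direction, and the group held at this carbon matters a great deal. Nothing among the data shown accounts for the size of the nitro for chloro step.

From the compounds shown here alone, whether this gain is particular to nitro remains open, as a single exchange cannot show how the number follows the group on this carbon; an amine, a carboxylic acid or a methoxy group here would begin to settle that. Going by these compounds, compound 2 differs from compound 1 in two places, so the share of its fluoro group cannot be separated from the change in the core, and whether nitro would give a similar step on the core of compound 2 also stays unknown.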